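Removing the piperidine amide from compound 1

The source may report more compounds than this note shows. Statements on the series, on what has been measured and on what is new or still open speak of the compounds shown alone.

In a functional assay on U-87MG ATCC cells for inhibition, with U-87 MG (Homo sapiens) as the target, read by MTT assay, with a stated time of 72 h (on this read-out higher numbers stand for weaker inhibition and lower numbers for stronger inhibition), compound 1 `COc1ccccc1-c1csc2cnc(Nc3ccc(NC(=O)C4CCNCC4)cc3)nc12` gives 1060 nM as the highest of the three numbers. Compound 2 `COc1ccccc1-c1csc2cnc(Nc3ccc(NC(=O)[C@H]4CCCNC4)cc3)nc12` gives 300 nM and compound 3 `COc1ccccc1-c1csc2cnc(Nc3ccc(NC(=O)[C@@H]4CCCNC4)cc3)nc12` gives 360 nM in this assay as well. Piperidin-3-yl in place of piperidin-4-yl brings a 3.5-fold lower number from compound 1 to compound 2 (0.55 log units; beyond the scatter) and a 2.9-fold lower number from compound 1 to compound 3 (0.47 log units; beyond the scatter) as modest steps, while configuration alone gives a 1.2-fold higher number from compound 2 to compound 3 (0.08 log units; within the scatter) and no more. Compound 4 `CNC(=O)c1ccc(Nc2ncc3scc(-c4ccccc4OC)c3n2)cc1` has methylcarbamoyl in place of ((piperidin-4-yl)carbonyl)amino on an aromatic carbon, counted as methylcarbamoyl in place of ((piperidin-4-yl)carbonyl)amino on an aromatic carbon in all. Among the measured compounds shown here, no measured step removes the ring, so these steps guide size only loosely and leave the direction uncertain. Piperidin-3-yl alone gave a 2.9-fold lower number from compound 1 to compound 3 (0.47 log units; beyond the scatter) as a shift beyond the scatter, so a step of similar or larger size is expected, tentatively towards a higher number. The estimated step is a 2.4-fold higher number from compound 1 to compound 4 (0.37 log units; beyond the scatter) as a rough expectation. Compound 4 is estimated at 2500 nM with an expected range from 600 nM to 10000 nM for now.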

Compound 4, half-maximal inhibitory concentration: 710 nM
Compound 4: middle estimate off by 3.5-fold (0.55 log units), on the high side, within the range that was stated.
By their numbers in this assay, from the lowest: compounds 2, 3, 4 and 1 (each within the scatter of the next, the first and the last beyond it).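

Methylcarbamoyl, with no ring, reads much like the larger ((piperidin-4-yl)carbonyl)amino, with a 1.5-fold lower number from compound 1 to compound 4 (0.17 log units; within the scatter), so the ring of compound 1 brings no measurable gain at this position. Against ((piperidin-3-yl)carbonyl)amino the picture splits, with a 2.0-fold higher number from compound 3 to compound 4 (0.29 log units; within the scatter) but a 2.4-fold higher number from compound 2 to compound 4 (0.37 log units; beyond the scatter), and only the latter step shows a piperidine amide holding an advantage. Nothing shown accounts for these steps. Open, going by these compounds, is whether an amine on a longer chain, or a carboxylic acid, in place of methylcarbamoyl on this aromatic carbon would move the number beyond the scatter of compound 4.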